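Dropping the aminomethyl side chain from compound 2

The compounds below may be only part of what the source reports. "The series", "measured", "known", "first", "only" and "open" are said of these compounds alone.

In a functional assay on A549 cells (Homo sapiens) for antiproliferative activity, read by MTT assay, with a stated time of 72 h (a higher number here means a weaker inhibitor, a lower number a stronger inhibitor), compound 2 `O=C(Nc1cccc(CN2CCCC2)c1)Nc1ccc2ncnc(Nc3cccc(C(F)(F)F)c3)c2c1` gives 860 nM, and compound 1 `CN(C)Cc1ccc(NC(=O)Nc2ccc3ncnc(Nc4cccc(C(F)(F)F)c4)c3c2)cc1` gives 1120 nM; the two sit within the scatter of each other, the step being a 1.3-fold lower number from compound 1 to compound 2 (0.11 log units; within the scatter). Compound 3 `O=C(Nc1ccccc1)Nc1ccc2ncnc(Nc3cccc(C(F)(F)F)c3)c2c1` removes the side chain entirely: hydrogen in place of (pyrrolidin-1-yl)methyl on an aromatic carbon. Among the compounds with values here, the single measured step exchanges one amine-bearing group for another and leaves the number essentially where it was; no measured step removes such a group outright, so there is no direct precedent in this assay. For compound 3 the number is estimated at 1500 nM, with a range of 500 nM to 5000 nM. The expected step is a 1.7-fold higher number from compound 2 to compound 3 (0.24 log units; within the scatter), a modest weakening at most.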

Compound 3, half-maximal inhibitory concentration: > 10000 nM
Compound 3 gave a limit, no number; the forecaster's own chance of this, stated with the estimate: 5%; middle value at least 6.6-fold (0.82 log units) from the limit.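

Compound 3 gives only a limit in this assay, not a number: the limit of > 10000 nM in this assay, at which 1 of the 3 values shown sits.

Replacing the side chain with hydrogen therefore costs far more than exchanging one amine-bearing group for another: the change gives an at least 11-fold higher number from compound 2 to compound 3 (1.06 log units; beyond the scatter) and an at least 8.9-fold higher number from compound 1 to compound 3 (0.95 log units; beyond the scatter). The aromatic carbon carrying the side chain thus tolerates that exchange, but activity in this series does not survive outright removal.

Open, going by these compounds, is whether the side-chain nitrogen matters or any substituent would serve, as a methyl or hydroxymethyl group there would show. On these data alone, the full size of the loss also remains open.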